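The compounds below may be only part of what the source reports. "The series", "measured", "known", "first", "only" and "open" are said of these compounds alone.

Working notes on the series. The shared core carries a sulfonyl on one side and a bicyclic amine on the other; three analogues have numbers in a functional assay on DU-145 cells (Homo sapiens) for inhibition, read by trypan blue exclusion, with a stated time of 72 h; a higher number here means a weaker inhibitor, a lower number a stronger inhibitor. Compound 1 `Cn1c(=O)c(S(=O)(=O)c2ccc(Cl)cc2Cl)cc2cnc(Nc3ccc4[nH]ccc4c3)nc21` gives 1000 nM in this assay, the lowest number of the three. Compound 3 `Cn1c(=O)c(S(=O)(=O)c2ccccc2)cc2cnc(Nc3ccc4cc[nH]c4c3)nc21` gives 10000 nM, a higher number than compound 1, and compound 2 `Cn1c(=O)c(S(=O)(=O)c2ccc(F)cc2F)cc2cnc(Nc3ccc4[nH]ncc4c3)nc21` gives 30000 nM, higher again; both gaps lie beyond the scatter. Compounds 2 and 3 differ from compound 1 in more than one place, so no single step can be read from them.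

Compound 4 `Cc1ccc(S(=O)(=O)c2cc3cnc(Nc4ccc5[nH]ccc5c4)nc3n(C)c2=O)cc1` is not yet measured. It differs from compound 1 in one place: 4-methylphenyl in place of 2,4-dichlorophenyl on a sulfonyl sulfur. Among the measured compounds shown here, no comparable single step exists among the measured compounds; the only guide is that compound 3, with unsubstituted phenyl on the sulfonyl, gives 10000 nM against 1000 nM for compound 1. On that basis a modest weakening from compound 1 to compound 4 is expected, the step of a 3.0-fold higher number from compound 1 to compound 4 (0.48 log units; beyond the scatter). Compound 4 is therefore estimated at 3000 nM in this assay, within 1000 nM to 12000 nM.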

Compound 4, half-maximal inhibitory concentration: 750 nM
Beside the measured number, compound 4's estimate is 4.0-fold (0.60 log units) above it, and the stated range ends above it.
By their numbers in this assay, from the lowest: compounds 4 and 1 (each within the scatter of the next); then compound 3; then compound 2.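

In this assay, the change on a sulfonyl sulfur reads as a 1.3-fold lower number from compound 1 to compound 4 (0.12 log units; within the scatter), so with the rest of compound 1 held fixed, 4-methylphenyl and 2,4-dichlorophenyl are not told apart. Among the compounds shown here, this is the first single-place reading at this position, and it shows that the two chlorine atoms are not required to keep a number in this range. Steps to compound 2 and compound 3 still cannot be read, as each differs from compound 1 and compound 4 in more than one place, and nothing at hand gives a reason for the result.

Open, as far as these compounds go, is whether the same holds with a phenyl ring carrying an amine or a carboxylic acid, or with a longer alkyl chain on the sulfonyl sulfur. Also open, from the compounds shown here alone, is whether this step carries over to a different bicyclic amine on the shared core.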